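The source may report more compounds than this note shows. Statements on the series, on what has been measured and on what is new or still open speak of the compounds shown alone.

Measured in a functional assay (plasma) with Oryctolagus cuniculus as the target; a higher number here means a weaker inhibitor, a lower number a stronger inhibitor:
- compound 1 `Cc1nc2cnccc2n1C1CCN(C(=O)CC(c2ccccc2)c2ccccc2)CC1`: 100 nM
- compound 2 `Cc1nc2cnccc2n1CC1CCN(C(=O)C=C(c2ccccc2)c2ccccc2)CC1`: 240 nM
- compound 3 `Cc1nc2cnccc2n1CC1CCN(C(=O)CC(O)(c2ccccc2)c2ccccc2)CC1`: 640 nM

Of these three inhibitors, compound 3 shows the highest number, 640 nM, and so is the weakest of the set. Its gaps to compound 1 and compound 2 both lie beyond the usual scatter, but these compounds differ from it in more than one place, so neither gap isolates a single change.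

The next compound is compound 4 `Cc1nc2cnccc2n1CC1CCN(C(=O)CC(O)(c2ccccc2)C(F)(F)F)CC1`. It carries trifluoromethyl in place of phenyl on a saturated chain carbon bound to an aromatic carbon, an oxygen on a saturated carbon and a saturated chain carbon. Among the compounds with values here, no measured pair in this small set shows what such a replacement does, so any forecast is tentative. All three measured compounds carry a pair of phenyl groups, and compound 4 would be the first to keep only one. Starting from the 640 nM of compound 3, a move towards weaker inhibition beyond the scatter seems more likely than no change in this assay. The expected step is a 2.3-fold higher number from compound 3 to compound 4 (0.37 log units; beyond the scatter). For compound 4 the estimated value is 1500 nM, with an expected range from 400 nM to 6000 nM.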

Compound 4, half-maximal inhibitory concentration: 36 nM
For compound 4 the middle estimate is 42-fold (1.62 log units) above the measured one; the whole stated range lies above it.
By their numbers in this assay, from the lowest: compound 4; then compound 1; then compound 2; then compound 3.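

In this assay, within the data shown here, the first single change that can be read shows that this position does not need a second phenyl: putting trifluoromethyl in its place gives an 18-fold lower number from compound 3 to compound 4 (1.25 log units; beyond the scatter), a large step beyond the scatter. Compound 1, compound 2 and compound 3 all carry a pair of phenyl groups, so they could not show this; compound 4 shows that, at least with the oxygen kept on this carbon, a group with no ring and fewer heavy atoms can replace one phenyl and inhibition still improves. Nothing at hand accounts for the size of this step.

On these data alone, it remains open whether the gain comes from the presence of trifluoromethyl or simply from the loss of phenyl, a distinction that a methyl group or a cyclohexyl ring at the same place would help to draw. As far as these compounds go, it is equally open whether the same exchange would carry over to a compound without the oxygen on this carbon, or whether a fluorine or an amine in place of that oxygen would keep the lower number seen for compound 4.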